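Three Pyrazole Chalcones and an Unmeasured Difluoro Analogue

A few compounds are considered here, and "the series" means these few. Any claim that something is new, unique, unknown or untested is made for them only; others in the source may bear on it.

Measured compounds:
- compound 1 `COc1cc(-c2cc(/C=C/C(=O)c3ccc(N)cc3)[nH]n2)cc(OC)c1OC`: 47500 nM
- compound 2 `COc1ccc(-c2cc(/C=C/C(=O)c3ccc(OC)c(OC)c3)[nH]n2)cc1`: 30000 nM
- compound 3 `COc1ccc(-c2cc(/C=C/C(=O)c3ccc(N)cc3)[nH]n2)cc1OC`: 53900 nM

All three share one core and differ only in the groups on its two outer rings. In a functional assay on MDA-MB-231 cells (Homo sapiens) for inhibition, read by sulforhodamine B assay, with a stated time of 48 h (on this read-out higher numbers stand for lower toxicity in this test and lower numbers for higher toxicity in this test), compound 1 stands second highest of the three numbers. Its nearest neighbour is compound 3, reached by a 1.1-fold higher number from compound 1 to compound 3 (0.05 log units; within the scatter), a change on the ring carrying the methoxy groups. Compound 2 gives the lowest number of the three, and its gap to compound 1 lies within the scatter, so no order among the three can be claimed.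

Compound 4 `COc1cc(-c2cc(/C=C/C(=O)c3ccc(F)c(F)c3)[nH]n2)cc(OC)c1OC` is not yet measured. It arises from compound 1 through (3,4-difluorophenyl in place of 4-aminophenyl on a carbonyl carbon). Among the measured compounds shown here, no measured step touches the group on the carbonyl carbon alone, since compound 2 differs from compound 1 at both rings at once. With nothing of the kind to lean on, the expectation is a step from compound 1 to compound 4 of a 1.2-fold lower number from compound 1 to compound 4 (0.07 log units; within the scatter), which is within the scatter. Compound 4 is therefore estimated at 40000 nM, with a range from 15000 nM to 100000 nM.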

Compound 4, concentration lethal to 50% of the cells: > 100000 nM
Compound 4: a limit, no number; the forecaster's own chance of this, stated with the estimate: 10%; middle value at least 2.5-fold (0.39 log units) from the limit.
By their numbers in this assay, from the lowest: compounds 2, 1 and 3 (each within the scatter of the next). At a limit, above all of these: compound 4.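

Compound 4 gives > 100000 nM in this assay, which is a limit of the assay and not a number. Putting 3,4-difluorophenyl in place of 4-aminophenyl on the carbonyl carbon gives an at least 2.1-fold higher number from compound 1 to compound 4 (0.32 log units; beyond the scatter), the first step shown that changes this group alone and the first to pass the scatter, whereas the change on the methoxy ring gave a 1.1-fold higher number from compound 1 to compound 3 (0.05 log units; within the scatter). On this read-out a higher number stands for lower toxicity in this test, so this position does respond to the change, but the full size of the step cannot be read: the limit of > 100000 nM in this assay, at which 1 of the 4 values shown sits.

On these data alone, whether the step comes from losing the amino group or from gaining the two fluorines stays open, and a plain phenyl group on the carbonyl carbon would help separate the two. Also open, as far as these compounds go, is whether the same change made on compound 3 gives a step of similar size.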